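The source may report more compounds than this note shows. Statements on the series, on what has been measured and on what is new or still open speak of the compounds shown alone.

Of the compounds shown here, three sharing one core have been measured so far. Compound 1 `O=S(=O)(c1ccc(Br)cc1)n1cnc2ccccc21`, compound 2 `O=S(=O)(c1cccc(C(F)(F)F)c1)n1cnc2ccccc21` and compound 3 `Cc1cc(C)c(C)c(S(=O)(=O)n2cnc3ccccc32)c1C` were tested in an ADME assay on Vero cells (Chlorocebus sabaeus) for cytotoxicity, read by flow cytometry and propidium iodide staining, with a stated time of 72 h; a lower number here means a stronger inhibitor, a higher number a weaker inhibitor. Compound 1 gives 1190000 nM, the highest number of the three; compound 3 gives 205000 nM and compound 2 gives 59800 nM, both separated from compound 1 by more than the usual scatter. Compound 4 `O=[N+]([O-])c1ccc(S(=O)(=O)n2cnc3ccccc32)cc1` has not yet been measured in this assay. It differs from compound 1 by nitro in place of bromo on an aromatic carbon. Going by the values given here, no pair of measured compounds differs in only one place, so no measured step guides this change. A modest fall in the number, somewhat beyond the scatter, is expected, giving the step of a 3.0-fold lower number from compound 1 to compound 4 (0.47 log units; beyond the scatter). Compound 4 is estimated at 400000 nM, within 80000 nM to 2000000 nM.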

Compound 4, half-maximal inhibitory concentration: 347000 nM
Beside the measured number, compound 4's estimate is 1.2-fold (0.06 log units) above it; the measured number falls inside the stated range.
By their numbers in this assay, from the lowest: compound 2; then compounds 3 and 4 (each within the scatter of the next); then compound 1.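

In this assay, going by these compounds alone, nitro in place of bromo on an aromatic carbon, para to a large group, gives a 3.4-fold lower number from compound 1 to compound 4 (0.54 log units; beyond the scatter) and is the first change in a single place that can be read here. It shows that the number responds modestly to the group at this position, with the larger group of the two giving the lower number. No measurement shown explains this step. Going by these compounds, whether an amine or a carboxylic acid at this position would lower the number further remains open, as does the effect of a longer chain there.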